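Replacing a methylphenyl amide group with a fluorophenyl one

This account rests on a few compounds, and the source may have more. Where it says the series, first, only, none or still open, it means among the compounds named here.

Measured compounds:
compound 1 `Cc1c(C(=O)Nc2ccc(C(F)(F)F)cc2)cnn1Cc1ccc(F)cc1` gives 3600 nM
compound 2 `Cc1c(C(=O)N(CC(=O)O)c2ccc(C(F)(F)F)cc2)cnn1-c1ccc(F)cc1` gives 3200 nM
compound 3 `Cc1ccc(NC(=O)c2cnn(-c3ccc(F)cc3)c2C)cc1` gives 540 nM

In a functional assay with Homo sapiens as the target (a higher number here means a weaker inhibitor, a lower number a stronger inhibitor), compound 3 stands lowest of the three measured values, so it is the strongest inhibitor among them; compound 2 and compound 1 both lie well beyond the usual scatter above it. Among the measured compounds shown here, compound 3 differs from those two in more than one place at once, so none of the measured pairs isolates a single change.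

Compound 4 `Cc1c(C(=O)Nc2ccccc2F)cnn1-c1ccc(F)cc1` has not yet been measured. It differs from compound 3 in one place: 2-fluorophenyl in place of 4-methylphenyl on an amide-type nitrogen. For the measured compounds named here, no measured pair shows this kind of exchange on an amide-type nitrogen. The expectation therefore rests only on the position of compound 3 in this assay. The step from compound 3 to compound 4 is expected to be a 2.8-fold higher number from compound 3 to compound 4 (0.44 log units; beyond the scatter), a moderate weakening that may well still fall near the scatter. Compound 4 is therefore estimated to give 1500 nM in this assay, within a range from 400 nM to 6000 nM.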

Compound 4, half-maximal inhibitory concentration: 4000 nM
Compound 4: middle estimate off by 2.7-fold (0.43 log units), on the low side, within the range that was stated.
By their numbers in this assay, from the lowest: compound 3; then compounds 2, 1 and 4 (each within the scatter of the next).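

In this assay, among the compounds shown here, this is the first comparison that changes only one place, and it shows that the group on the amide-type nitrogen matters. Putting 2-fluorophenyl in place of 4-methylphenyl gives a 7.4-fold higher number from compound 3 to compound 4 (0.87 log units; beyond the scatter), a change well beyond the scatter, even though both groups have the same count of heavy atoms and neither has a hydrogen-bond donor or acceptor. Nothing available here explains this weakening.

This single exchange removes one group and brings in another, so it leaves open whether the result reflects the loss of 4-methylphenyl or the arrival of 2-fluorophenyl. An unsubstituted phenyl group at this position, or a phenyl ring carrying a methoxy group or an amine, would help separate these two readings.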